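The source may hold more compounds than are shown below. What is called first, only, known or untested is meant among the compounds shown, and "the series" means these compounds.

Measured compounds:
- compound 1 `CNC(=O)[C@H]1O[C@@H](n2cnc3c(NC)nc(C#Cc4ccc(F)s4)nc32)[C@H](O)[C@@H]1O` — 2.3 nM
- compound 2 `CNC(=O)[C@@]12C[C@@H]1[C@@H](n1cnc3c(NC)cc(C#Cc4ccc(F)s4)nc31)[C@H](O)[C@@H]2O` — 0.896 nM
- compound 3 `CNC(=O)[C@H]1O[C@@H](n2cnc3c(NC)cc(C#Cc4ccc(F)s4)nc32)[C@H](O)[C@@H]1O` — 26.6 nM

All three were run in an assay on CHO cells for displacement of a labelled ligand from adenosine receptor A3 (Homo sapiens); a higher number here means a weaker inhibitor, a lower number a stronger inhibitor. Among them compound 1 sits second highest of the three numbers: the nearest is compound 2, whose number is lower, and the furthest is compound 3, whose number is higher; both gaps lie beyond the scatter. Among the compounds with values here, compound 2 and compound 3 differ from compound 1 in more than one place, so no single-point step between measured compounds is available.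

The next compound, compound 4 `CCCNc1nc(C#Cc2ccc(F)s2)nc2c1ncn2[C@@H]1O[C@H](C(=O)NC)[C@@H](O)[C@H]1O`, differs from compound 1 in one place: ethyl in place of hydrogen on a saturated chain carbon bound to a nitrogen on an aromatic ring. Cut one bond further out, the change reads methylamino to propylamino. Nothing measured in the series tests this chain length directly, so the expectation rests on the value of compound 1 alone and on the general tendency of small changes at a saturated chain carbon bound to a nitrogen on an aromatic ring to shift the number modestly rather than drastically.

The step from compound 1 to compound 4 in this assay is expected to be a moderate rise, a 3.5-fold higher number from compound 1 to compound 4 (0.54 log units; beyond the scatter), with a weaker inhibitor the more likely outcome. Compound 4 is therefore estimated at 8 nM, in the range 2 nM to 35 nM.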

Compound 4, inhibition constant: 8.51 nM
Estimate against measurement, compound 4: 1.1-fold (0.03 log units) below, within the range that was stated.
By their numbers in this assay, from the lowest: compound 2; then compound 1; then compound 4; then compound 3.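

In this assay, within the data shown here, going from methylamino to propylamino gives a 3.7-fold higher number from compound 1 to compound 4 (0.57 log units; beyond the scatter), the first single-point reading, as the earlier compounds differ from one another in more than one place. The step lies beyond the scatter yet is modest, so ethyl in place of hydrogen on a saturated chain carbon bound to a nitrogen on an aromatic ring costs something at this position without a drastic change in the number. Nothing available accounts for the rise.

On these data alone, two chain lengths fix no trend, so it remains open how butylamino, the branched isopropylamino or cyclopropylamino would compare at this position. As far as these compounds go, it is also open whether the same change would read alike on the cores of compound 2 and compound 3, both of which carry methylamino.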